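Notes on a bromophenyl swap in the series

The compounds below may be only part of what the source reports. "The series", "measured", "known", "first", "only" and "open" are said of these compounds alone.

compound 1 `NC1=NC2(CCSCC2)N(OCCCOc2cccc(Cl)c2)C(N)=N1` gives 260 nM
compound 2 `NC1=NC2(CCOCC2)N(OCCCOc2ccc(Cl)cc2Cl)C(N)=N1` gives 330 nM

Among the compounds with values here, both values come from a functional assay on HL-60 cells (Homo sapiens) for antiproliferative activity, read by MTT assay, with a stated time of 72 h (on this read-out lower numbers stand for stronger inhibition and higher numbers for weaker inhibition), and lie within the usual scatter of each other, so compound 1 stands level with compound 2, the only other measured compound. Next comes compound 3 `NC1=NC2(CCSCC2)N(OCCCOc2ccccc2Br)C(N)=N1`, which keeps the core of compound 1 and carries 2-bromophenyl in place of 3-chlorophenyl on an oxygen on a saturated carbon. Within the data shown here, no measured pair isolates a change in this group, so the data give no direct size for the step. Compound 1 differs from compound 2 in more than one place, and compound 2 still gives 330 nM so only a small step in this assay is expected, perhaps toward weaker inhibition and perhaps none beyond the scatter. The expected change is a 1.2-fold higher number from compound 1 to compound 3 (0.09 log units; within the scatter) by estimate. For compound 3 the estimate is 320 nM with a range from 110 nM to 900 nM expected.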

Compound 3, half-maximal inhibitory concentration: 180 nM
Compound 3: the middle estimate sits 1.8-fold (0.25 log units) above what was measured, and the stated range covers the measured number.
By their numbers in this assay, from the lowest: compounds 3, 1 and 2 (each within the scatter of the next).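

Within the data shown here, this is the first step that isolates the group on this oxygen: in this assay, 2-bromophenyl in place of 3-chlorophenyl on an oxygen on a saturated carbon gives a 1.4-fold lower number from compound 1 to compound 3 (0.16 log units; within the scatter). With the core of compound 1 held fixed, the read-out therefore stays level across this change, and both groups are accepted at this position within the scatter. No measured evidence bears on why the two groups read alike.

The halogen and its place on the phenyl ring change together here, so 2-chlorophenyl and 3-bromophenyl would be needed to separate the two changes. From the compounds shown here alone, it also remains open whether a different kind of group on this oxygen, such as a pyridyl ring, or a phenyl ring carrying an amine or a carboxylic acid, would move the number beyond the scatter.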